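The compounds below may be only part of what the source reports. "The series", "measured", "known", "first", "only" and "open" are said of these compounds alone.

Compound 3 `S=C(SCc1cn(Cc2ccc(Cl)c(Cl)c2)nn1)N1CCNCC1` carries a 3,4-dichlorophenyl group on the saturated chain carbon bound to the aromatic nitrogen and an unsubstituted piperazine ring at the other end of the shared core. In a functional assay on MGC-803 cells (Homo sapiens) for inhibition, read by MTT assay, with a stated time of 72 h (a higher number here means a weaker inhibitor, a lower number a stronger inhibitor), compound 3 is reported as "not determined" (no result reported), so its own standing cannot be read from any number. Among the compounds with values here, the only values available come from relatives that keep a protecting group on the piperazine nitrogen: compound 1 `Cc1ccc(Cn2cc(CSC(=S)N3CCN(C(=O)OC(C)(C)C)CC3)nn2)cc1` gives 3490 nM in this assay, and compound 2 `Cc1ccc(Cn2cc(CSC(=S)N3CCN(C(=O)OCc4ccccc4)CC3)nn2)cc1` gives 9370 nM. Within the data shown here, the single computed step, a 2.7-fold higher number from compound 1 to compound 2 (0.43 log units; beyond the scatter), concerns the group on the oxygen of the carbamate and not the part of the molecule that changes here.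

Compound 4 `Cc1ccc(Cn2cc(CSC(=S)N3CCNCC3)nn2)cc1` arises from compound 3 by the change (4-methylphenyl in place of 3,4-dichlorophenyl on a saturated chain carbon bound to an aromatic nitrogen). Among the measured compounds shown here, no measured pair shows what this swap does, and the loss of the carbamate that separates compound 4 from compound 1 is likewise untested. The expectation for compound 4 therefore rests loosely on compound 1, whose 3490 nM is the closest anchor, and is given with a wide range. Compound 4 is expected to give about 5000 nM in this assay, estimated to lie between 1200 nM and 25000 nM.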

Compound 4, half-maximal inhibitory concentration: 64300 nM
Estimate against measurement, compound 4: 13-fold (1.11 log units) below; measured number outside the range, above it.
By their numbers in this assay, from the lowest: compound 1; then compound 2; then compound 4.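

In this assay, the free ring nitrogen of compound 4 goes with much weaker inhibition than either protected relative: hydrogen in place of tert-butoxycarbonyl on this amine nitrogen gives an 18-fold higher number from compound 1 to compound 4 (1.27 log units; beyond the scatter), and hydrogen in place of benzyloxycarbonyl gives a 6.9-fold higher number from compound 2 to compound 4 (0.84 log units; beyond the scatter). Within the data shown here, the earlier comparison showed only that the group on the carbamate oxygen alters the reading, whereas these steps show that losing the whole carbamate alters it more, with both protected compounds giving lower numbers than compound 4. No measured information here explains why the numbers move this way.

Without a number for compound 3, the effect of 4-methylphenyl in place of 3,4-dichlorophenyl on a saturated chain carbon bound to an aromatic nitrogen cannot be read, and neither can any step involving compound 3. From the compounds shown here alone, it also remains open whether a simpler group on the ring nitrogen, such as methyl or acetyl, would give a number nearer those of the carbamates or nearer that of the free amine.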